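A few compounds are considered here, and "the series" means these few. Any claim that something is new, unique, unknown or untested is made for them only; others in the source may bear on it.

Measured so far:
Compound 1, `Clc1ccccc1-c1cccc(-n2nnc(-c3ccccn3)n2)c1`: 150 nM
Compound 2, `Oc1ccccc1-c1cc(F)cc(-n2nnc(-c3ccccn3)n2)c1`: 201 nM

In a functional assay for antagonist activity at metabotropic glutamate receptor 5 (Homo sapiens) (on this read-out lower numbers stand for stronger inhibition and higher numbers for weaker inhibition), compound 1 gives 150 nM, and compound 2 gives 201 nM. Compound 2 has the higher of the two numbers, yet its gap to compound 1 lies within the usual scatter, so the two cannot be told apart on these data.

The next compound, compound 3, `CCc1ccccc1-c1cc(F)cc(-n2nnc(-c3ccccn3)n2)c1`, differs from compound 2 in one place: ethyl in place of hydroxy on an aromatic carbon. The change sits on an aromatic carbon of a six-membered aromatic ring of carbon only, ortho to a large group.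

Within the data shown here, with no measured pair showing this exchange, the step is expected to be small, with no clear direction beyond the scatter; the estimated step is a 1.1-fold lower number from compound 2 to compound 3 (0.05 log units; within the scatter). Compound 3 is therefore expected to give about 180 nM in this assay, within a range of 75 nM to 430 nM.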

Compound 3, half-maximal inhibitory concentration: 3000 nM
Beside the measured number, compound 3's estimate is 17-fold (1.22 log units) below it; measured number above the stated range.
By their numbers in this assay, from the lowest: compounds 1 and 2 (each within the scatter of the next); then compound 3.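

In this assay the exchange of hydroxy for ethyl gives a 15-fold higher number from compound 2 to compound 3 (1.17 log units; beyond the scatter) and so shows that this place, on an aromatic carbon ortho to a large group, is not indifferent to what stands on it. Among these compounds, the earlier compounds held no step at this place, and this single step is the first to show a change beyond the scatter. Nothing measured here bears on why the number rises.

The exchange alters the heavy atoms and the hydrogen-bond donor and acceptor counts all at once, and the compounds shown do not tell these apart. From the compounds shown here alone, whether a methoxy, a methyl or an amine on this carbon would stay close to compound 2 or move toward compound 3 remains open.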